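Third hydroxy placement on the shared core

The source may report more compounds than this note shows. Statements on the series, on what has been measured and on what is new or still open speak of the compounds shown alone.

Compound 1, `O=C(/C=C/c1cccc(F)c1)c1ccccc1`, was tested in a functional assay on RAW264.7 cells (Mus musculus) for inhibition, read by fluorescence, with stated times of 1 h, 24 h and 30 min; a higher number here means a weaker inhibitor, a lower number a stronger inhibitor. In this assay compound 1 gives only a limit, > 10000 nM. Compound 2, `O=C(/C=C/c1cccc(F)c1)c1ccccc1O`, carries a hydroxy in place of hydrogen on an aromatic carbon; in this assay compound 2 likewise gives a limit, > 10000 nM. Compound 3, `O=C(/C=C/c1cccc(F)c1)c1cccc(O)c1`, carries the hydroxy on a different aromatic carbon; in this assay compound 3 also gives a limit, > 10000 nM. The steps a step that the two limits leave unreadable from compound 1 to compound 2 and a step that the two limits leave unreadable from compound 1 to compound 3 stay unreadable because of the limit of > 10000 nM in this assay, at which 3 of the 3 values shown sit. Compound 4, `O=C(/C=C/c1cccc(F)c1)c1ccc(O)cc1`, differs from compound 1 by hydroxy in place of hydrogen on an aromatic carbon. Both measured hydroxy placements left the limit untouched, so no step beyond the scatter is expected. Compound 4 is therefore estimated at 10000 nM, between 3000 nM and 30000 nM. The expected step of a number no higher from compound 1 to compound 4 (the limit leaves the size open) amounts to none beyond the scatter.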

Compound 4, half-maximal inhibitory concentration: 9150 nM
The estimate for compound 4 lay 1.1-fold (0.04 log units) above the measured number; measured number inside the range.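

In this assay, the hydroxy para to a large group is the only one of the three placements on the shared core that gives a number rather than a limit, and this change gives an at least 1.0-fold lower number from compound 1 to compound 4 (0.03 log units; that floor lies within the scatter). The printed figure is only a floor, and the full size of the step stays open because compound 1 has no number of its own: the limit of > 10000 nM in this assay, at which 3 of the 4 values shown sit.

The compounds shown leave open whether a methoxy or an amine on this same carbon would also give a number. They also leave open whether either group would move it beyond the scatter.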